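Phenyl in place of trimethylpropyl on the shared core

This account rests on a few compounds, and the source may have more. Where it says the series, first, only, none or still open, it means among the compounds named here.

Compound 1 `CC[C@@H](Nc1n[s+]([O-])nc1Nc1cccc(C(=O)N(C)C)c1O)c1ccc(C)o1`: 234 nM
Compound 2 `CC[C@@H](Nc1n[s+]([O-])nc1Nc1cccc(C(=O)N(C)C)c1O)c1cc(C(C)C)co1`: 61 nM
Compound 3 `C[C@H](Nc1n[s+]([O-])nc1Nc1cccc(C(=O)N(C)C)c1O)C(C)(C)C`: 484 nM

Of the compounds shown here, three sharing one core have been measured in an assay on isolated protein for binding affinity to C-X-C chemokine receptor type 1 (Homo sapiens); a lower number here means a stronger inhibitor, a higher number a weaker inhibitor. Compound 3 stands highest of the three numbers; compound 1 is nearest to it, as a 2.1-fold higher number from compound 1 to compound 3 (0.32 log units; beyond the scatter) shows, and compound 2 is furthest. Compound 4 `CC[C@@H](Nc1n[s+]([O-])nc1Nc1cccc(C(=O)N(C)C)c1O)c1ccccc1` differs from compound 3 in one place: 1-phenylpropyl in place of 1,2,2-trimethylpropyl on a nitrogen on an aromatic ring. Within the data shown here, two measured steps bear on this change. a 2.1-fold higher number from compound 1 to compound 3 (0.32 log units; beyond the scatter) shows that an aromatic ring on the chain carbon, in place of the trimethylpropyl branch, gives a lower number, and a 3.8-fold lower number from compound 1 to compound 2 (0.58 log units; beyond the scatter) shows that the ring can be varied with a further modest gain. A modest step toward a lower number is therefore expected, a 3.0-fold lower number from compound 3 to compound 4 (0.48 log units; beyond the scatter). Compound 4 is estimated at 160 nM, within 50 nM to 500 nM.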

Compound 4, inhibition constant: 1220 nM
Estimate against measurement, compound 4: 7.6-fold (0.88 log units) below, outside the stated range (above it).
By their numbers in this assay, from the lowest: compound 2; then compound 1; then compound 3; then compound 4.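

In this assay, an aromatic ring on the chain carbon did not by itself give a lower number: 1-phenylpropyl in place of 1,2,2-trimethylpropyl raised it (a 2.5-fold higher number from compound 3 to compound 4 (0.40 log units; beyond the scatter)). Phenyl also stood well behind both substituted furans (a 5.2-fold higher number from compound 1 to compound 4 (0.72 log units; beyond the scatter); a 20-fold higher number from compound 2 to compound 4 (1.30 log units; beyond the scatter)), so at this position the lower numbers belong to the furan-bearing compounds, not to aromatic rings in general. Nothing available explains these steps.

Going by these compounds, it remains open whether isopropyl or an amine on the phenyl ring would recover the lower numbers. Also open, on these data alone, is how an unsubstituted furan-2-yl would compare.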